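The source may report more compounds than this note shows. Statements on the series, on what has been measured and on what is new or still open speak of the compounds shown alone.

Measured in a functional assay on MCF7 cells (Homo sapiens) for antiproliferative activity, read by sulforhodamine B assay, with a stated time of 48 h; on this read-out lower numbers stand for stronger inhibition and higher numbers for weaker inhibition:
- Compound 1 `Cc1cc(C)cc(NS(=O)(=O)c2ccc(N3CCNC3=O)cc2)c1`: 100 nM
- Compound 2 `O=C1NCCN1c1ccc(S(=O)(=O)Nc2ccc(Cl)cc2)cc1`: 170 nM
- Compound 3 `O=C1NCCN1c1ccc(S(=O)(=O)Nc2ccc(Br)cc2)cc1`: 240 nM

Compound 3, at 240 nM, is clearly separated from only one of the other two compounds. The first gap is small, a 1.4-fold higher number from compound 2 to compound 3 (0.15 log units; within the scatter), while the second is modest, a 2.4-fold higher number from compound 1 to compound 3 (0.38 log units; beyond the scatter).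

The next compound, compound 4 `Cc1ccc(NS(=O)(=O)c2ccc(N3CCNC3=O)cc2)c(C)c1`, has not yet been measured. Its change is 2,4-dimethylphenyl in place of 4-bromophenyl on a sulfonamide nitrogen, with 2,4-dimethylphenyl in place of 4-bromophenyl on a sulfonamide nitrogen. For the measured compounds named here, the closest evidence comes from compound 1, the only measured compound with a dimethylphenyl group, and that comparison is the modest step already given. Going by the values given here, it is only a partial guide, since compound 1 carries 3,5-dimethylphenyl and no measured compound carries 2,4-dimethylphenyl. A small shift towards a lower number in this assay is therefore expected, probably not beyond the scatter. The expected change is a 1.6-fold lower number from compound 3 to compound 4 (0.20 log units; within the scatter). For compound 4 the estimated value is 150 nM, with an expected range of 55 nM to 420 nM.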

Compound 4, half-maximal inhibitory concentration: 230 nM
Estimate against measurement, compound 4: 1.5-fold (0.19 log units) below, within the range that was stated.
By their numbers in this assay, from the lowest: compounds 1, 2, 4 and 3 (each within the scatter of the next, the first and the last beyond it).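

In this assay, 2,4-dimethylphenyl on the sulfonamide nitrogen gives a 1.0-fold lower number from compound 3 to compound 4 (0.02 log units; within the scatter) and a 1.4-fold higher number from compound 2 to compound 4 (0.13 log units; within the scatter), so at this place it cannot be told apart from 4-bromophenyl or 4-chlorophenyl. A dimethylphenyl group alone therefore does not reproduce the number of compound 1: the change from 3,5-dimethylphenyl to 2,4-dimethylphenyl gives a 2.3-fold higher number from compound 1 to compound 4 (0.36 log units; beyond the scatter), which separates two groups made of the same atoms. Nothing available explains this difference between the two dimethylphenyl groups.

The compounds shown leave open how an unsubstituted phenyl or a phenyl with a single methyl would compare with these groups on the sulfonamide nitrogen. They also do not show what an amine, a carboxylic acid or a longer chain on that ring would do to the number in this assay.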